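Chloro in place of hydrogen on two related cores

The source may report more compounds than this note shows. Statements on the series, on what has been measured and on what is new or still open speak of the compounds shown alone.

Measured so far in a functional assay on the whole organism with Rattus norvegicus as the target; a higher number here means a weaker inhibitor, a lower number a stronger inhibitor:
- compound 1, `Cc1ccc(O)c(NCCCN2CCC(C(O)(c3ccccc3)c3ccccc3)CC2)c1`, gives 0.029 ug/mL
- compound 2, `Cc1ccc(O)c(NCCCN2CCC(C(O)(c3ccccc3)c3ccc(Cl)cc3)CC2)c1`, gives 0.041 ug/mL
- compound 3, `Cc1ccc(O)c(NCCCN2CCC(OC(c3ccccc3)c3ccccc3)CC2)c1`, gives 0.036 ug/mL

Compound 2 differs from compound 1 by chloro in place of hydrogen on an aromatic carbon; the measured step is a 1.4-fold higher number from compound 1 to compound 2 (0.15 log units; within the scatter). Compound 3 has the same atoms as compound 1 joined differently; the difference between the two cores is not broken down here. Compound 4, `Cc1ccc(O)c(NCCCN2CCC(OC(c3ccccc3)c3ccc(Cl)cc3)CC2)c1`, is not yet measured and differs from compound 3 by chloro in place of hydrogen on an aromatic carbon, the same change at a place described in the same words. The expectation rests on compound 1 and compound 2, whose step a 1.4-fold higher number from compound 1 to compound 2 (0.15 log units; within the scatter) stayed within the scatter, so a step of similar size, a 1.4-fold higher number from compound 3 to compound 4 (0.14 log units; within the scatter), is expected from compound 3 to compound 4. For compound 4 the estimate in this assay is 0.05 ug/mL, expected to fall between 0.025 ug/mL and 0.1 ug/mL.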

Compound 4, half-maximal inhibitory concentration: 0.084 ug/mL
Estimate against measurement, compound 4: 1.7-fold (0.23 log units) below; the measured number falls inside the stated range.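

In this assay chloro in place of hydrogen gives a 2.3-fold higher number from compound 3 to compound 4 (0.37 log units; beyond the scatter) on this core, while the same change on the core of compound 1 stays within the scatter. Set side by side, the two steps cannot be told apart: the same change on two cores in this assay, a 1.4-fold higher number (0.15 log units; within the scatter) from compound 1 to compound 2 and a 2.3-fold higher number (0.37 log units; beyond the scatter) from compound 3 to compound 4, 1.7-fold (0.22 log units) apart, within the scatter of two such steps

The result fits a single step size on both cores, but one pair per core does not establish that the steps are equal, nor that the change would behave the same way on a further core.

Going by these compounds, what fluoro or methoxy would give in place of the chloro stays open. So does the effect of a longer chain in place of the propyl chain on either core.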